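The source may report more compounds than this note shows. Statements on the series, on what has been measured and on what is new or still open speak of the compounds shown alone.

Measured in an ADME assay on CHO cells (Cricetulus griseus) for cytotoxicity, read by LDH release; on this read-out lower numbers stand for stronger inhibition and higher numbers for weaker inhibition:
Compound 1 `CC(Oc1ccc(Cl)cc1Cl)C(=O)NC(C)c1ccc(F)cc1`: > 100000 nM
Compound 2 `CC(Oc1ccc(Cl)cc1Cl)C(=O)NC(c1ccc(F)cc1)C(C)C`: > 100000 nM
Compound 3 `CC(Oc1ccc(Cl)cc1Cl)C(=O)NC(c1ccc(F)cc1)C1CC1`: > 100000 nM

Each of these values is a limit of the assay and not a number. Compound 3 stands on (the limit of > 100000 nM in this assay, at which 3 of the 3 values shown sit).

The next compound, compound 4 `CCCCC(NC(=O)C(C)Oc1ccc(Cl)cc1Cl)c1ccc(F)cc1`, keeps the rest of the structure and changes one group: butyl in place of cyclopropyl on a saturated chain carbon bound to an amide-type nitrogen and an aromatic carbon. In words, butyl takes the place of cyclopropyl on a saturated chain carbon bound to an amide-type nitrogen and an aromatic carbon.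

Three measured steps change the group at this same place: a step that the two limits leave unreadable from compound 1 to compound 2, a step that the two limits leave unreadable from compound 1 to compound 3 and a step that the two limits leave unreadable from compound 2 to compound 3. None of them has a size that can be read, so they give no direction for the new change. They offer no sign of a step beyond the scatter either.

The expected step is a number no higher from compound 3 to compound 4 (the limit leaves the size open), with no direction foreseen. For compound 4 the estimate is 100000 nM, with an expected range from 40000 nM to 200000 nM.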

Compound 4, half-maximal inhibitory concentration: > 100000 nM
Compound 4: a limit, no number; the forecaster's own chance of this, stated with the estimate: 80%; the middle value sits exactly at the limit.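

In this assay compound 4 gives > 100000 nM, a limit of the assay and not a number. Its steps from compound 1, compound 2 and compound 3 therefore cannot be read. The compounds shown leave open whether methyl, isopropyl, cyclopropyl and butyl differ at all at this place, and all of them share one result: the limit of > 100000 nM in this assay, at which 4 of the 4 values shown sit.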